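The source may report more compounds than this note shows. Statements on the series, on what has been measured and on what is new or still open speak of the compounds shown alone.

Working notes on the shared core. Among the compounds with values here, all three compounds measured so far were run in an ADME assay on BJ cells (Homo sapiens), read by MTT assay, with a stated time of 72 h; on this read-out higher numbers stand for weaker inhibition and lower numbers for stronger inhibition. Compound 1 `Nc1nc(N)c2c(-c3ccsc3)cn([C@@H]3O[C@H](CO)[C@@H](O)[C@H]3O)c2n1` gives in this assay only the assay limit of > 100000 nM. Compound 2 `CNc1ncnc2c1c(-c1cccs1)cn2[C@@H]1O[C@H](CO)[C@@H](O)[C@H]1O` likewise stops at the limit, > 100000 nM. Compound 3 `Cc1nc(N)c2c(-c3ccsc3)cn([C@@H]3O[C@H](CO)[C@@H](O)[C@H]3O)c2n1` also reaches no number and sits at the limit of > 100000 nM. The step that the two limits leave unreadable from compound 1 to compound 3 is unreadable for that reason, as the limit of > 100000 nM in this assay, at which 3 of the 3 values shown sit, records. Compound 4 `Cc1nc(N)c2c(I)cn([C@@H]3O[C@H](CO)[C@@H](O)[C@H]3O)c2n1` differs from compound 3 by iodo in place of thiophen-3-yl on an aromatic carbon. Within the data shown here, no measured step bears on this change, and with every value shown sitting at the limit no direction can be read from the data. For compound 4 the expectation in this assay is again a limit, estimated at 100000 nM with a range from 30000 nM to 300000 nM. The expected step of a number no higher from compound 3 to compound 4 (the limit leaves the size open) is accordingly nil beyond the scatter.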

Compound 4, half-maximal inhibitory concentration: 24600 nM
Estimate against measurement, compound 4: 4.1-fold (0.61 log units) above; the measured number lies below the stated range.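

In this assay, iodo in place of thiophen-3-yl on an aromatic carbon gives an at least 4.0-fold lower number from compound 3 to compound 4 (0.60 log units; beyond the scatter), so this position can shift the read-out away from the limit. The earlier step cannot be read: the limit of > 100000 nM in this assay, at which 3 of the 4 values shown sit. From the compounds shown here alone, the starting point of the new step is itself a limit, so its full size stays open.

Going by these compounds, whether the shift follows from the loss of thiophen-3-yl or from iodo itself remains open, and bromo, chloro or ethynyl at this position would separate the two. Also open, on these data alone, is whether iodo gives a similar shift with amino in place of the methyl on the core.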